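Swapping the large group on the triazole-type nitrogen

This account rests on a few compounds, and the source may have more. Where it says the series, first, only, none or still open, it means among the compounds named here.

- compound 1 `CN1C(=S)[C@@H](NC(=O)c2nc(Cc3ccccc3)n(C)n2)COc2ccccc21` gives 2.5 nM
- compound 2 `CN1C(=S)[C@@H](NC(=O)c2nc(Cc3ccccc3)n(C3CCNCC3)n2)COc2ccccc21` gives 1000 nM
- compound 3 `CN1C(=S)[C@@H](NC(=O)c2nc(Cc3ccccc3)n(Cc3ccccc3)n2)COc2ccccc21` gives 414 nM

In a functional assay on HT-29 cells (Homo sapiens) for inhibition, read by luminescence and CellTiter-Glo, with a stated time of 24 h (a higher number here means that more compound is needed for the effect, a lower number that less compound is needed), compound 3 stands at 414 nM as second highest of the three numbers, nearest to compound 2 and far above compound 1. Compound 4 `Cc1cnc(-n2nc(C(=O)N[C@H]3COc4ccccc4N(C)C3=S)nc2Cc2ccccc2)nc1` is not yet measured. Its change is 5-methylpyrimidin-2-yl in place of benzyl on an aromatic nitrogen and it puts 5-methylpyrimidin-2-yl in place of benzyl on an aromatic nitrogen.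

The closest measured step is a 2.4-fold lower number from compound 2 to compound 3 (0.38 log units; beyond the scatter) and it is modest, one large group replacing another on that nitrogen. Two large steps start from the methyl group on the same nitrogen: a 400-fold higher number from compound 1 to compound 2 (2.60 log units; beyond the scatter) and also a 170-fold higher number from compound 1 to compound 3 (2.22 log units; beyond the scatter) and the new group resembles neither methyl nor a small group in size. Among the measured compounds shown here, no measured compound carries a six-membered aromatic ring with hetero atoms there, so the range stays wide. The expected move is a 1.1-fold higher number from compound 3 to compound 4 (0.04 log units; within the scatter) in this assay and no clear step beyond the scatter is expected. The estimate for compound 4 is 450 nM with an expected range of 80 nM to 2500 nM for the measurement.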

Compound 4, half-maximal effective concentration: 1950 nM
Beside the measured number, compound 4's estimate is 4.3-fold (0.64 log units) below it; the measured number falls inside the stated range.
By their numbers in this assay, from the lowest: compound 1; then compound 3; then compounds 2 and 4 (each within the scatter of the next).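

In this assay, benzyl and 5-methylpyrimidin-2-yl carry the same count of heavy atoms, yet the exchange gives a 4.7-fold higher number from compound 3 to compound 4 (0.67 log units; beyond the scatter), so size measured this way does not settle the number at this position. The step of a 2.0-fold higher number from compound 2 to compound 4 (0.29 log units; within the scatter) stays within the scatter, which leaves 5-methylpyrimidin-2-yl and piperidin-4-yl indistinguishable here despite their different rings. Methyl remains the only group on this nitrogen with a low number, and a 780-fold higher number from compound 1 to compound 4 (2.89 log units; beyond the scatter) joins the two large steps already seen from compound 1, with no listed compound going against this pattern.

No measurement available here bears on the cause of these differences. As far as these compounds go, how the number moves between methyl and the larger groups remains open, as ethyl, a longer chain or cyclopropyl on this nitrogen would show.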